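This account rests on a few compounds, and the source may have more. Where it says the series, first, only, none or still open, it means among the compounds named here.

Measured so far in a functional assay on U-87MG ATCC cells for antiproliferative activity against U-87 MG (Homo sapiens), read by MTT assay, with a stated time of 48 h, tested at 10 uM; a lower number here means a stronger effect, a higher number a weaker effect of the compound at the concentration tested:
compound 1 `COc1ccc(-c2nc(C)c(C(=O)CSc3nc(-c4ccc(Cl)cc4)c(C#N)c(=O)[nH]3)s2)cc1` gives 92.7%
compound 2 `COc1ccc(-c2nc(C)c(C(=O)CSc3nc(-c4ccc(OC)cc4)c(C#N)c(=O)[nH]3)s2)cc1` gives 80.3%
compound 3 `Cc1nc(-c2ccc(Cl)cc2)sc1C(=O)CSc1nc(-c2ccc(Cl)c(Cl)c2)c(C#N)c(=O)[nH]1` gives 97.1%

Compound 3 holds the highest of the three numbers in this assay, but its gap to compound 1 is within the scatter; only the gap to compound 2 lies beyond it.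

Compound 4 `COc1ccc(-c2nc(C)c(C(=O)CSc3nc(-c4ccc(Cl)c(Cl)c4)c(C#N)c(=O)[nH]3)s2)cc1` differs from compound 3 by one change: methoxy in place of chloro on an aromatic carbon. For the measured compounds named here, the only measured step of the same kind is a number 12.4 percentage points lower from compound 1 to compound 2 (beyond the scatter), which sits on the other aryl ring of the shared core, so it bears on the present step only loosely. On that basis a modest lowering of the number is expected, of about a number 9.1 percentage points lower from compound 3 to compound 4 (within the scatter). Compound 4 is therefore estimated at 88% in this assay, with a range from 76% to 99%.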

Compound 4, a percentage reported as activity, at one concentration (the size of the read-out at that concentration, not a potency): 88.6%
Compound 4: the middle estimate sits 0.6 percentage points below what was measured, and the stated range covers the measured number.
By their numbers in this assay, from the lowest: compounds 2, 4, 1 and 3 (each within the scatter of the next, the first and the last beyond it).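

In this assay the change from 4-chlorophenyl to 4-methoxyphenyl, now read on a second aryl ring, gives a number 8.5 percentage points lower from compound 3 to compound 4 (within the scatter). The change therefore has two readings of similar size, though only one lies beyond the scatter: the same change on two cores in this assay, a number 12.4 percentage points lower (beyond the scatter) from compound 1 to compound 2 and a number 8.5 percentage points lower (within the scatter) from compound 3 to compound 4, 3.9 percentage points apart, within the scatter of two such steps

On the other aryl ring, chloro in place of hydrogen gives a number 4.1 percentage points lower from compound 1 to compound 4 (within the scatter), and 3,4-dichlorophenyl in place of 4-methoxyphenyl gives a number 8.3 percentage points higher from compound 2 to compound 4 (within the scatter), so neither exchange stands clear of the scatter.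

From the compounds shown here alone, whether an amine or a carboxylic acid in place of chloro would move the number further remains open.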